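A few compounds are considered here, and "the series" means these few. Any claim that something is new, unique, unknown or untested is made for them only; others in the source may bear on it.

In a functional assay on HeLa cells (Homo sapiens) for cytotoxicity, read by WST assay, with a stated time of 48 h (a higher number here means a weaker inhibitor, a lower number a stronger inhibitor), compound 1, `COc1cc(C(c2ccc(O)c(OC)c2)[C@H](C)[C@H](C)CO)ccc1O`, gives > 100000 nM, which is a limit of the assay rather than a number. Compound 3, `COc1cc(C(c2ccc(O)c(OC)c2)[C@@H](C)[C@H](C)CO)ccc1O`, also gives > 100000 nM in this assay, again a limit. Compound 2, `COc1cc(C(c2ccc(O)c(OC)c2)[C@H](CF)C(C)C)ccc1O`, gives 19000 nM in this assay. Between these three the measured steps are an at least 5.2-fold lower number from compound 1 to compound 2 (0.72 log units; beyond the scatter), an at least 5.2-fold higher number from compound 2 to compound 3 (0.72 log units; beyond the scatter) and a step that the two limits leave unreadable from compound 1 to compound 3. Compound 1 thus stands only at a limit, and its gap to compound 3 cannot be read because the limit of > 100000 nM in this assay, at which 2 of the 3 values shown sit, leaves no number on either side, while the pair differ only because the fact that compounds 1 and 3 differ only in the configuration as drawn holds.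

The compound not yet measured is compound 4, `CC[C@H](C(C)C)C(c1ccc(O)c(OC)c1)c1ccc(O)c(OC)c1`. It differs from compound 1 by 1-isopropylpropyl in place of 2-(hydroxymethyl)-1-methylpropyl on a saturated chain carbon bound to two aromatic carbons. The measured step that bears on this change is an at least 5.2-fold lower number from compound 1 to compound 2 (0.72 log units; beyond the scatter), in which the 2-(hydroxymethyl)-1-methylpropyl likewise left the saturated chain carbon bound to two aromatic carbons and a branched chain without a hydroxyl entered. Compound 4 removes the hydroxymethyl in the same way, so a step in the same direction, of at least modest size, is expected. Compound 4 is therefore expected to show an at least 4.0-fold lower number from compound 1 to compound 4 (0.60 log units; beyond the scatter) in this assay. Compound 4 is estimated at 25000 nM in this assay, with a range from 6000 nM to 100000 nM.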

Compound 4, half-maximal inhibitory concentration: 9700 nM
Estimate against measurement, compound 4: 2.6-fold (0.41 log units) above; the measured number falls inside the stated range.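

In this assay, 1-isopropylpropyl in place of 2-(hydroxymethyl)-1-methylpropyl on a saturated chain carbon bound to two aromatic carbons gives an at least 10-fold lower number from compound 1 to compound 4 (1.01 log units; beyond the scatter), and the same change gives an at least 10-fold lower number from compound 3 to compound 4 (1.01 log units; beyond the scatter), so the change reads the same from either configuration drawn. The fluoro of the earlier measured compound proves not to be needed for a measurable value, since methyl in its place gives a 2.0-fold lower number from compound 2 to compound 4 (0.29 log units; within the scatter), and this leaves no difference that can be read between the two chains without a hydroxymethyl. Among the compounds shown, only those carrying 2-(hydroxymethyl)-1-methylpropyl stand at a limit of the assay, and none goes against this: the limit of > 100000 nM in this assay, at which 2 of the 4 values shown sit.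

Going by these compounds alone, what configuration does at this chain stays unread, as the only pair that tests it stands at that limit on both sides: the fact that compounds 1 and 3 differ only in the configuration as drawn. Also open, on these data alone, is how a chain ending in an amine or a carboxylic acid, or a longer chain, would read at this place in this assay.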